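The source may hold more compounds than are shown below. What is called first, only, known or untested is meant among the compounds shown, and "the series" means these compounds.

Working notes on the series. In a functional assay on Vero cells (Chlorocebus sabaeus) for inhibition (on this read-out higher numbers stand for weaker inhibition and lower numbers for stronger inhibition), compound 1 (`Nc1nc(O)c2ncn([C@@H]3O[C@@H](CO)C=C3F)c2n1`) gives > 100000 nM, which is a limit of the assay and not a number. Compound 2 (`Nc1nc(Cl)c2ncn([C@H]3O[C@@H](CO)C=C3F)c2n1`) gives > 100000 nM, likewise only a limit. Going by the values given here, it therefore stands with the only other compound measured, and no number places it more exactly: the limit of > 100000 nM in this assay, at which 2 of the 2 values shown sit.

Compound 3 (`Nc1nc(Cl)c2ncn([C@@H]3O[C@@H](CO)C=C3F)c2n1`) is the next to be read in this assay. Its relation to compound 2 is purely one of configuration: the two compounds have the same atoms and bonds and differ only in configuration as drawn: 1 of 2 stereo elements differ; a stereocentre at a saturated ring carbon is drawn S in compound 2 and R in compound 3. A stereocentre at a saturated ring carbon is drawn S in compound 2 and R in compound 3, and nothing enters or leaves.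

Among the compounds with values here, no measured step shows what such an inversion does. The expectation rests on compound 2, whose reading of > 100000 nM is a limit. No change beyond the scatter is expected, and the most likely result is another limit. The estimated change is an at least 1.1-fold lower number from compound 2 to compound 3 (0.04 log units; that floor lies within the scatter), with any real movement more likely towards stronger inhibition, since the limit leaves no room to show the opposite. For compound 3 the expected value is 90000 nM, with an estimated range of 25000 nM to 150000 nM.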

Compound 3, half-maximal inhibitory concentration: > 100000 nM
Compound 3 ended at the assay's limit; the forecaster's own chance of this, stated with the estimate: 70%; middle value at least 1.1-fold (0.04 log units) away from the limit.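

In this assay compound 3 gives > 100000 nM, a limit of the assay and not a number. The steps from compound 2 and from compound 1 to compound 3 therefore cannot be read. The compounds shown leave open whether the inversion at the saturated ring carbon, or chloro in place of hydroxy, changes inhibition at all.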